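The compounds below may be only part of what the source reports. "The series", "measured", "known", "first", "only" and "open" are said of these compounds alone.

In an assay on microsomes from intestine for inhibition of acyl-CoA:cholesterol acyltransferase (Oryctolagus cuniculus) (on this read-out lower numbers stand for stronger inhibition and higher numbers for weaker inhibition), compound 1 `CCCCCCCCCCCCC(C)OC(=O)NC(=O)Nc1c(C(C)C)cccc1C(C)C` gives 46 nM. Compound 2 `CCCCCCCCCCCCC(C)(C)OC(=O)NC(=O)Nc1c(C(C)C)cccc1C(C)C` carries methyl in place of hydrogen on a saturated chain carbon bound to an oxygen next to a carbonyl group and two saturated chain carbons; in this assay compound 2 gives 65 nM, so that the step is a 1.4-fold higher number from compound 1 to compound 2 (0.15 log units; within the scatter). Compound 3 `CCCCCCCCCCCCC(C)OC(=O)NC(=O)Oc1c(C(C)C)cccc1C(C)C` differs from compound 1 in its core; the difference between the two cores is not broken down here. In this assay compound 3 gives 17 nM, the lowest number of the three, beyond the scatter from both compound 1 and compound 2. Compound 4 `CCCCCCCCCCCCC(C)(C)OC(=O)NC(=O)Oc1c(C(C)C)cccc1C(C)C` is not yet measured; it carries methyl in place of hydrogen on a saturated chain carbon bound to an oxygen next to a carbonyl group and two saturated chain carbons, the same change as from compound 1 to compound 2, at the same place. Within the data shown here, the expected step in this assay is a 1.4-fold higher number from compound 3 to compound 4 (0.13 log units; within the scatter), resting on the step of a 1.4-fold higher number from compound 1 to compound 2 (0.15 log units; within the scatter), with the reservation that only that one pair is known. Compound 4 is thus expected to give about 23 nM in this assay, between 10 nM and 55 nM.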

Compound 4, half-maximal inhibitory concentration: 21 nM
Compound 4: middle estimate off by 1.1-fold (0.04 log units), on the high side, and the stated range covers the measured number.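

In this assay the methyl in place of hydrogen gives a 1.2-fold higher number from compound 3 to compound 4 (0.09 log units; within the scatter). The same change reads alike on the two cores shown, with no difference between the steps beyond the scatter: the same change on two cores in this assay, a 1.4-fold higher number (0.15 log units; within the scatter) from compound 1 to compound 2 and a 1.2-fold higher number (0.09 log units; within the scatter) from compound 3 to compound 4, 1.1-fold (0.06 log units) apart, within the scatter of two such steps. This supports carrying the change between these two cores only, as a change that leaves the number within the scatter on each; two pairs in one assay do not show that it would behave the same way on any other core.

The compounds shown leave open whether an ethyl group or a fluorine atom on that same carbon would give a step of similar size. Also open, on these data alone, is what a shorter chain, a longer chain or a terminal carboxylic acid would do on either core.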